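Chloro for Methyl on the Aryl Ring: Expected Effect

The source may hold more compounds than are shown below. What is called first, only, known or untested is meant among the compounds shown, and "the series" means these compounds.

Measured compounds:
- compound 1 `Cc1ccc(-n2cc(C(=O)Nc3cc(F)cc(F)c3)c(=O)c3ccc(N(C)C)nc32)cc1OCCCCCCC[N+]1(C)CCCC1`: 12.7%
- compound 2 `CN(C)c1ccc2c(=O)c(C(=O)Nc3cc(F)cc(F)c3)cn(-c3ccc(Cl)c(OCCCCCCC[N+]4(C)CCCC4)c3)c2n1`: 51%
- compound 3 `Cc1cc(OCCCCCCC[n+]2ccccc2)ccc1-n1cc(C(=O)Nc2cc(F)cc(F)c2)c(=O)c2ccc(N(C)C)nc21`: "not active" (no number reported)

In an assay on LX2 cells for inhibition of COL1A1 promoter (Homo sapiens), read by a luciferase reporter, with a stated time of 24 h, tested at 20 uM (on this read-out lower numbers stand for a weaker effect and higher numbers for a stronger effect at the one concentration tested), compound 1 gives 12.7%, while compound 2 gives 51%. The two differ only by chloro in place of methyl on an aromatic carbon, and that step is a number 38.3 percentage points higher from compound 1 to compound 2 (beyond the scatter). Compound 3 gives "not active" (no number reported) in this assay; the difference between the core of compound 3 and that of compound 1 is not broken down here. Compound 4 `CN(C)c1ccc2c(=O)c(C(=O)Nc3cc(F)cc(F)c3)cn(-c3ccc(OCCCCCCC[n+]4ccccc4)cc3Cl)c2n1` has not yet been tested. It differs from compound 3 by chloro in place of methyl on an aromatic carbon. This is the same kind of change as in compound 1 to compound 2, though around the place the surroundings differ: para to a large group in one case, meta to a large group in the other. A rise is expected for compound 4, resting on compound 1 to compound 2 showing a number 38.3 percentage points higher from compound 1 to compound 2 (beyond the scatter), yet smaller, since compound 3 starts from no reported number. Compound 4 is estimated at 30%, between 5% and 60%.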

Compound 4, a percentage reported as inhibition, at one concentration (the size of the read-out at that concentration, not a potency): "not active" (no number reported)
No number was reported for compound 4, and the estimate cannot be compared.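

Compound 3 and compound 4 both lack a reported number, so no step can be read between them, and no other data here bear on this result. Left open is what chloro in place of methyl does within this pair.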